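Compound 3 gives way to a 5-acetylfuran-2-yl group

A few compounds are considered here, and "the series" means these few. Any claim that something is new, unique, unknown or untested is made for them only; others in the source may bear on it.

In an in vitro ADME assay on microsomes from liver (Simiiformes) (a higher number here means that the compound lasts longer, a lower number that the compound disappears faster), compound 1 `COCc1cc(CCCOc2c(C)cc(-c3noc(C(F)(F)F)n3)cc2C)on1` gives 1.58 h. Compound 2 `CCOCc1cc(CCCOc2c(C)cc(-c3noc(C(F)(F)F)n3)cc2C)on1` gives > 2.5 h, which is a limit. Compound 3 `Cc1cc(-c2noc(C(F)(F)F)n2)cc(C)c1OCCCc1cc(C[S+](C)[O-])no1` gives > 2.5 h, also a limit. Compound 3 thus stands at the limit of > 2.5 h in this assay, at which 2 of the 3 values shown sit. Compound 4 `CC(=O)c1ccc(CCCOc2c(C)cc(-c3noc(C(F)(F)F)n3)cc2C)o1` differs from it as follows: a group of 8 heavy atoms (6 carbon, 2 oxygen; one five-membered aromatic ring with 1 hetero atom) in place of a group of 9 heavy atoms (5 carbon, 1 nitrogen, 2 oxygen, 1 sulfur; one five-membered aromatic ring with 2 hetero atoms), on a saturated chain carbon, three bonds along the chain from an oxygen on an aromatic ring. Among the compounds with values here, two measured steps bear on this change, an at least 1.5-fold higher number from compound 1 to compound 2 (0.19 log units; that floor lies within the scatter) and an at least 1.5-fold higher number from compound 1 to compound 3 (0.19 log units; that floor lies within the scatter), yet neither replaces the five-membered aromatic ring itself. The nearest true number is compound 1 at 1.58 h, so a similar value is expected. The expected change is an at least 1.5-fold lower number from compound 3 to compound 4 (0.19 log units; that floor lies within the scatter), downward but of uncertain size. Compound 4 is estimated at 1.6 h, with an expected range of 0.7 h to 3.5 h.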

Compound 4, half-life: 1.05 h
Compound 4: the middle estimate sits 1.5-fold (0.18 log units) above what was measured; low and high end bracket the measured number.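

In this assay, 5-acetylfuran-2-yl on this saturated chain carbon gives an at least 2.3-fold lower number from compound 3 to compound 4 (0.37 log units; beyond the scatter) and an at least 2.3-fold lower number from compound 2 to compound 4 (0.37 log units; beyond the scatter). Against 3-(methoxymethyl)-1,2-oxazol-5-yl, the same group gives a 1.5-fold lower number from compound 1 to compound 4 (0.18 log units; within the scatter), so a different five-membered aromatic ring at this position need not move the half-life beyond the scatter. Compound 2 and compound 3 each stand only as a limit: the limit of > 2.5 h in this assay, at which 2 of the 4 values shown sit.

On these data alone, whether the lower numbers follow the furan ring or the acetyl group stays open. Also open, as far as these compounds go, is how a furan carrying an amide in place of the acetyl would compare.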